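The source may hold more compounds than are shown below. What is called first, only, known or untested is meant among the compounds shown, and "the series" means these compounds.

Values in a functional assay on HCT-116 cells (Homo sapiens) for inhibition, read by CCK-8 assay, with a stated time of 48 h (on this read-out higher numbers stand for weaker inhibition and lower numbers for stronger inhibition), for the measured compounds:
- compound 1 `COc1cc(-c2ccnc3cc(-c4c[nH]c5ccccc45)nn23)cc(OC)c1OC` gives 35 nM
- compound 2 `Cn1ccc2cc(-c3cc4nccc(-c5ccc(F)cc5)n4n3)ccc21` gives 2160 nM
- compound 3 `COc1cc(-c2ccnc3cc(-c4ccccc4)nn23)cc(OC)c1OC` gives 3880 nM

Compound 3 shares the weak end of this small set with compound 2, since their two values lie within the scatter of each other. Compound 1 stands well apart, and the gap is a 110-fold higher number from compound 1 to compound 3 (2.04 log units; beyond the scatter) in size.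

Compound 4 `COc1cc(-c2ccnc3cc(-c4cccc(C)c4)nn23)cc(OC)c1OC` departs from compound 3 in one place (methyl in place of hydrogen on an aromatic carbon, or phenyl to 3-methylphenyl) methyl in place of hydrogen on an aromatic carbon and nothing else changes.

Among the compounds with values here, only one measured step touches this group, namely a 110-fold higher number from compound 1 to compound 3 (2.04 log units; beyond the scatter) and it is large. Within the data shown here, that step swaps the whole group, however, and no measured pair tests a methyl, so it shows only that the group matters. A small step in this assay is therefore expected, within the scatter and with no firm direction, and the estimated step is a 1.3-fold lower number from compound 3 to compound 4 (0.11 log units; within the scatter) in size.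

For compound 4 the expected value is 3000 nM with an estimated range of 1000 nM to 8000 nM in this assay.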

Compound 4, half-maximal inhibitory concentration: 6150 nM
Compound 4: middle estimate off by 2.1-fold (0.31 log units), on the low side; measured number inside the range.
By their numbers in this assay, from the lowest: compound 1; then compounds 2, 3 and 4 (each within the scatter of the next, the first and the last beyond it).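

In this assay, within the data shown here, the step of a 1.6-fold higher number from compound 3 to compound 4 (0.20 log units; within the scatter) is the first measured test of a small group at this position, and it lies within the scatter: a methyl meta to a large group leaves the reading of compound 4 indistinguishable from that of compound 3. The large gap remains, at a 180-fold higher number from compound 1 to compound 4 (2.24 log units; beyond the scatter), so this methyl does not bring the 3-methylphenyl compound anywhere near the 1H-indol-3-yl compound. Nothing available explains either step.

As far as these compounds go, whether an amine, a hydroxyl or a methoxy on that same aromatic carbon would leave the value as unchanged as the methyl does remains open. So does the question of whether a replacement for the 1H-indol-3-yl group, such as a benzimidazole or a pyridine, could approach compound 1.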